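The source may report more compounds than this note shows. Statements on the series, on what has been measured and on what is new or still open speak of the compounds shown alone.

Series notes in an ADME assay on HEK293 cells (Homo sapiens) for cytotoxicity, read by resazurin assay, with a stated time of 48 h; on this read-out higher numbers stand for lower toxicity in this test and lower numbers for higher toxicity in this test.
Compound 1 `O=S(=O)(Nc1ccc2oc(-c3ccccc3)nc2c1)c1ccccc1O`: 33000 nM.
Compound 2 `O=S(=O)(Nc1ccc2oc(-c3ccccc3)nc2c1)c1ccc(Cl)c(Cl)c1`: 71000 nM.
Compound 3 `Cc1cccc(S(=O)(=O)Nc2ccc3oc(-c4ccccc4)nc3c2)c1`: 69000 nM.

Compound 3 sits at the upper end of the three numbers alongside compound 2, the two separated only by a 1.0-fold lower number from compound 2 to compound 3 (0.01 log units; within the scatter); compound 1 lies lower, the gap being a 2.1-fold higher number from compound 1 to compound 3 (0.32 log units; beyond the scatter). Compound 4 `O=S(=O)(Nc1ccc2oc(-c3ccccc3)nc2c1)c1cccs1` differs from compound 3 as follows: thiophen-2-yl in place of 3-methylphenyl on a sulfonyl sulfur. Within the data shown here, no measured step brings a thiophen-2-yl onto the sulfonyl sulfur, so the steps that bear on it are those changing that same group: a 2.1-fold higher number from compound 1 to compound 3 (0.32 log units; beyond the scatter), a modest step, and a 1.0-fold lower number from compound 2 to compound 3 (0.01 log units; within the scatter), within the scatter. On that basis compound 4 is expected to show little or no change beyond the scatter, a 1.3-fold lower number from compound 3 to compound 4 (0.10 log units; within the scatter). Compound 4 is estimated at 55000 nM, within 25000 nM to 120000 nM.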

Compound 4, half-maximal cytotoxic concentration: 97000 nM
The estimate for compound 4 lay 1.8-fold (0.25 log units) below the measured number, within the range that was stated.
By their numbers in this assay, from the lowest: compound 1; then compounds 3, 2 and 4 (each within the scatter of the next).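

In this assay, thiophen-2-yl on a sulfonyl sulfur shows that a five-membered aromatic ring holding sulfur fits the same band as 3-methylphenyl and 3,4-dichlorophenyl, with a 1.4-fold higher number from compound 3 to compound 4 (0.15 log units; within the scatter) and a 1.4-fold higher number from compound 2 to compound 4 (0.14 log units; within the scatter) as the two steps. Only 2-hydroxyphenyl stands apart, and a 2.9-fold higher number from compound 1 to compound 4 (0.47 log units; beyond the scatter) is the widest step yet at this position. No evidence is available to explain these differences. The compounds shown leave open how an amine or a carboxylic acid on the aromatic ring would read, and how a saturated ring or an alkyl chain on the sulfonyl sulfur would compare. They also do not separate the ring size of thiophen-2-yl from its sulfur atom.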